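The source may hold more compounds than are shown below. What is called first, only, known or untested is meant among the compounds shown, and "the series" means these compounds.

Of the compounds shown here, two of a shared core have been measured in a functional assay on thoracic aorta (strain Wistar) with Aorta (Rattus norvegicus) as the target, with a stated time of 2 h; a lower number here means a stronger inhibitor, a higher number a weaker inhibitor. Compound 1 `CCOC(=O)c1c(-c2ccc(F)cc2)cc(-c2ccccc2)nc1Nc1ccccc1` gives 367000 nM in this assay. Compound 2 `CCOC(=O)c1c(-c2ccc(F)cc2)cc(-c2ccccc2)nc1Nc1ccc(Cl)cc1`, which carries a chloro in place of hydrogen on an aromatic carbon, gives 715000 nM in this assay. Of the two numbers, that of compound 2 is the larger, but the step of a 1.9-fold higher number from compound 1 to compound 2 (0.29 log units; within the scatter) lies within the scatter of repeated measurements, so the two compounds cannot be told apart on these data.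

Compound 3 `CCOC(=O)c1c(-c2ccc(F)cc2)cc(-c2ccccc2)nc1Nc1ccc(OC)cc1` has not yet been measured. It differs from compound 2 in one place: methoxy in place of chloro on an aromatic carbon. For the measured compounds named here, no measured step shows what an exchange of chloro for methoxy does here; the only step in hand, a 1.9-fold higher number from compound 1 to compound 2 (0.29 log units; within the scatter), concerns a different exchange at the same place and was within the scatter. With nothing pointing in either direction, the expected step of a 1.4-fold lower number from compound 2 to compound 3 (0.16 log units; within the scatter) in this assay is none beyond the scatter. Compound 3 is therefore estimated to give 500000 nM in this assay, with a range from 180000 nM to 1400000 nM.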

Compound 3, half-maximal inhibitory concentration: 254000 nM
Compound 3: middle estimate off by 2.0-fold (0.29 log units), on the high side; low and high end bracket the measured number.
By their numbers in this assay, from the lowest: compounds 3, 1 and 2 (each within the scatter of the next, the first and the last beyond it).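

In this assay this position, para to a large group on a six-membered aromatic ring of carbon only, now gives its first step beyond the scatter: methoxy in place of chloro brings a 2.8-fold lower number from compound 2 to compound 3 (0.45 log units; beyond the scatter) and so marks a modest but readable difference. Set against the compound with hydrogen at this place, methoxy gives a 1.4-fold lower number from compound 1 to compound 3 (0.16 log units; within the scatter) and so cannot be told apart from it, just as chloro could not with a 1.9-fold higher number from compound 1 to compound 2 (0.29 log units; within the scatter) in the earlier comparison. The position therefore separates the two substituents from each other while neither separates from hydrogen, a picture that rests on these three compounds alone.

From the compounds shown here alone, whether other groups here, such as an amine, a carboxylic acid or a longer alkoxy chain, would move the number further in either direction stays open, as does whether the exchange of chloro for methoxy would give a similar step on another core. Nothing in hand offers a measured reason for the gap between chloro and methoxy.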